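Working notes: the amine substituent of compound 2

The source may report more compounds than this note shows. Statements on the series, on what has been measured and on what is new or still open speak of the compounds shown alone.

Measured so far in a functional assay on MCF7 cells (Homo sapiens) for antiproliferative activity; a lower number here means a stronger inhibitor, a higher number a weaker inhibitor:
compound 1 `CC(C)=CCc1cc(C(=O)Nc2cc3ccc(OCCCNCC(C)C)c(C)c3oc2=O)ccc1O`: 1320 nM
compound 2 `CC(C)=CCc1cc(C(=O)Nc2cc3ccc(OCCCNC(C)(C)c4ccccc4)c(C)c3oc2=O)ccc1O`: 1070 nM

Compound 2, at 1070 nM, lies within the scatter of compound 1, so these two numbers do not rank the pair. The next compound to be measured, compound 3 `CC(C)=CCc1cc(C(=O)Nc2cc3ccc(OCCCN[C@@H]4C[C@H]5CC[C@@H]4C5)c(C)c3oc2=O)ccc1O`, keeps the core of compound 2 and differs only in the substituent on the amine nitrogen: a group of 7 heavy atoms (7 carbon; 2 five-membered non-aromatic rings of carbon only) in place of a group of 9 heavy atoms (9 carbon; one six-membered aromatic ring of carbon only), on an amine nitrogen.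

Within the data shown here, one measured step bears on this change, made at the same amine nitrogen: a 1.2-fold lower number from compound 1 to compound 2 (0.09 log units; within the scatter). That exchange of isobutyl for 1-methyl-1-phenylethyl stayed within the scatter. Among the measured compounds shown here, no measured compound carries the incoming group, so this single step is weak evidence. On that basis, no step beyond the scatter is expected in this assay, in either direction. The estimate corresponds to an expected step of a 1.1-fold higher number from compound 2 to compound 3 (0.05 log units; within the scatter). The expected value for compound 3 is 1200 nM, with an estimated range of 500 nM to 3000 nM.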

Compound 3, half-maximal inhibitory concentration: 1030 nM
Beside the measured number, compound 3's estimate is 1.2-fold (0.07 log units) above it; the range from low to high includes it.
By their numbers in this assay, from the lowest: compounds 3, 2 and 1 (each within the scatter of the next).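

In this assay, the group with 2 five-membered non-aromatic rings of carbon only, on an amine nitrogen, gives a 1.0-fold lower number from compound 2 to compound 3 (0.02 log units; within the scatter) when it replaces 1-methyl-1-phenylethyl, and a 1.3-fold lower number from compound 1 to compound 3 (0.11 log units; within the scatter) when it replaces isobutyl. The substituent at this nitrogen has now been an open chain, a group with an aromatic ring and a group with non-aromatic rings, with all three compounds within the scatter of each other, so the aromatic ring of compound 2 is not needed for a value of this size, and the earlier pair alone could not show that. The data shown offer no explanation for why these exchanges leave the number within the scatter.

On these data alone, all three substituents contain carbon only, so it remains open whether a hydroxyethyl group or a carboxylic acid at this nitrogen would also stay within the scatter. With 3 defined stereocentres in the incoming group and only one arrangement of them shown, the reading of its mirror-image form also remains open.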